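A few compounds are considered here, and "the series" means these few. Any claim that something is new, unique, unknown or untested is made for them only; others in the source may bear on it.

Of the compounds shown here, two with a shared sugar-bearing core have been measured in an assay on CHO-K1 cells for displacement of a labelled ligand from adenosine receptor A1 (Homo sapiens), read by scintillation counting, with a stated time of 60 min; on this read-out higher numbers stand for weaker inhibition and lower numbers for stronger inhibition. Compound 1 `CC(/C=N/Nc1nc(N)c2ncn([C@@H]3O[C@H](CO)[C@@H](O)[C@H]3O)c2n1)Cc1ccc(C(C)C)cc1` carries a branched, non-aromatic chain on the carbon with a double bond to nitrogen, and in this assay compound 1 gives 9500 nM. Compound 2 `Nc1nc(N/N=C/c2cccnc2Cl)nc2c1ncn2[C@@H]1O[C@H](CO)[C@@H](O)[C@H]1O` carries a 2-chloropyridin-3-yl group at that same position, and in this assay compound 2 gives 4.6 nM. Compound 2 therefore stands at the lower, stronger end of the two numbers, and the gap separating it from compound 1 lies well beyond the usual scatter of repeated measurements.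

Compound 3 `Nc1nc(N/N=C/c2ccc(C(F)(F)F)cc2)nc2c1ncn2[C@@H]1O[C@H](CO)[C@@H](O)[C@H]1O` has not yet been measured. It differs from compound 2 in one place: 4-(trifluoromethyl)phenyl in place of 2-chloropyridin-3-yl on a carbon with a double bond to nitrogen. The aromatic ring on the carbon with a double bond to nitrogen is kept, only its identity changes. Because compound 2 gives 4.6 nM with an aromatic ring there, while compound 1 with a non-aromatic chain gives 9500 nM, the aromatic ring appears to matter more than its exact substitution, so a modest step is expected, probably toward weaker inhibition, summarised as a 3.3-fold higher number from compound 2 to compound 3 (0.51 log units; beyond the scatter). Compound 3 is estimated at 15 nM, within a range from 3 nM to 80 nM.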

Compound 3, inhibition constant: 37 nM
Compound 3: middle estimate off by 2.5-fold (0.39 log units), on the low side, within the range that was stated.
By their numbers in this assay, from the lowest: compound 2; then compound 3; then compound 1.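

In this assay, the step of an 8.0-fold higher number from compound 2 to compound 3 (0.91 log units; beyond the scatter) shows that the number at this position responds to the identity of the aromatic ring, not just to its presence, since the two compounds with such a ring now differ by more than the usual scatter. Even so, compound 3 gives 37 nM and compound 1 gives 9500 nM, so this second aromatic group also gives a much lower number than the branched, non-aromatic chain. The change replaces the ring nitrogen and the chlorine and adds trifluoromethyl in a single move, and no measurement here explains the step or divides it among those parts.

The compounds shown leave open which part of the change carries the step, and 2-chlorophenyl, pyridin-3-yl or unsubstituted phenyl at this position would help separate those parts. They also leave open how the number responds when the ring carries a group of a different kind, such as an amine or a carboxylic acid.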